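The source may hold more compounds than are shown below. What is called first, only, known or untested is meant among the compounds shown, and "the series" means these compounds.

Measured compounds in a functional assay on MCF7 cells (Homo sapiens) for cytotoxicity, read by CellTiter-Glo, with a stated time of 5 days; on this read-out higher numbers stand for weaker inhibition and lower numbers for stronger inhibition:

compound 1 `COCC/C(=C(/c1ccc(/C=C/C(=O)O)cc1)c1ccc2[nH]ncc2c1)c1ccccc1`, 63 nM
compound 2 `O=C(O)/C=C/c1ccc(/C(=C(/CCO)c2ccccc2)c2ccc3[nH]ncc3c2)cc1`, a limit of this assay, > 1000 nM
compound 3 `O=C(O)/C=C/c1ccc(/C(=C(/CCF)c2ccccc2)c2ccc3[nH]ncc3c2)cc1`, 2.1 nM

Compound 3 holds the lowest number among the three; the nearest measured value is that of compound 1, and the step is a 30-fold lower number from compound 1 to compound 3 (1.48 log units; beyond the scatter). Compound 2 reports only a limit, (the limit of > 1000 nM in this assay, at which 1 of the 3 values shown sits), so the step to compound 3 is given as an at least 470-fold lower number from compound 2 to compound 3 (2.67 log units; beyond the scatter).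

Compound 4 `O=C(O)/C=C/c1ccc(/C(=C(\c2ccccc2)C2CCCCC2)c2ccc3[nH]ncc3c2)cc1` is not yet measured. The change from compound 3 is cyclohexyl in place of 2-fluoroethyl on a double-bonded chain carbon bound to an aromatic carbon and a double-bonded chain carbon. Among the compounds with values here, no measured step swaps the whole two-carbon chain for a ring; the steps that come closest, a 30-fold lower number from compound 1 to compound 3 (1.48 log units; beyond the scatter) and an at least 470-fold lower number from compound 2 to compound 3 (2.67 log units; beyond the scatter), alter only the end of that chain and were both large, as was an at least 15-fold higher number from compound 1 to compound 2 (1.20 log units; beyond the scatter). The series therefore shows this position to be sensitive, without indicating the direction for a cyclohexyl group. A large step beyond the scatter is expected; its sign is uncertain, and the estimate is placed toward a higher number, with a wide range.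

For compound 4 in this assay the expected value is 80 nM, between 8 nM and 800 nM, corresponding to an expected step of a 38-fold higher number from compound 3 to compound 4 (1.58 log units; beyond the scatter).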

Compound 4, half-maximal inhibitory concentration: 64 nM
Beside the measured number, compound 4's estimate is 1.3-fold (0.10 log units) above it; measured number inside the range.
By their numbers in this assay, from the lowest: compound 3; then compounds 1 and 4 (each within the scatter of the next). At a limit, above all of these: compound 2.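

In this assay a ring is accepted at this place on the double-bonded chain carbon, although exchanging 2-fluoroethyl for cyclohexyl gives a 30-fold higher number from compound 3 to compound 4 (1.48 log units; beyond the scatter) and leaves compound 3 alone at the low end. Cyclohexyl and 2-methoxyethyl cannot be told apart, with a 1.0-fold higher number from compound 1 to compound 4 (0.01 log units; within the scatter), and cyclohexyl stands clear of 2-hydroxyethyl, with an at least 15-fold lower number from compound 2 to compound 4 (1.19 log units; beyond the scatter), so a carbon-only group with no hydrogen-bond acceptor is compatible with activity here. Compound 2 reports only a limit: the limit of > 1000 nM in this assay, at which 1 of the 4 values shown sits.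

On these data alone, whether an unsubstituted ethyl, a cyclopropyl ring, or a longer chain ending in fluoro or an amine would match compound 3 remains open. Nothing shown here assigns a cause to these steps.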